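The source may hold more compounds than are shown below. What is called first, only, known or untested is meant among the compounds shown, and "the series" means these compounds.

Compound 1 `COC(=O)C1=C(C)N=C(C)/C(=C(\O)OC)C1c1cccc(Br)c1`: 1.29 nM
Compound 2 `CCOc1ccccc1C1C(C(=O)OC)=C(C)N=C(C)/C1=C(\O)OC`: 110 nM

In a functional assay (muscle tissue) with Cavia porcellus as the target (a higher number here means that more compound is needed for the effect, a lower number that less compound is needed), compound 1 gives 1.29 nM. Compound 2 stands highest of the two at 110 nM, and the gap between them lies beyond the scatter. Compound 3 `COC(=O)C1=C(C)N=C(C)/C(=C(\O)OC)C1c1ccccc1C#N` differs from compound 2 in one place, with cyano in place of ethoxy on an aromatic carbon, ortho to a large group: cyano in place of ethoxy on an aromatic carbon. Among the measured compounds shown here, no measured step covers this change, so the expectation is tentative. It rests on the wide room left below compound 2, given compound 1 at 1.29 nM. A downward move beyond the scatter is expected, estimated as a 9.2-fold lower number from compound 2 to compound 3 (0.96 log units; beyond the scatter). In this assay compound 3 is expected at 12 nM, within an estimated range of 2.5 nM to 60 nM.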

Compound 3, half-maximal effective concentration: 15.9 nM
For compound 3 the middle estimate is 1.3-fold (0.12 log units) below the measured one; measured number inside the range.
By their numbers in this assay, from the lowest: compound 1; then compound 3; then compound 2.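

In this assay, cyano in place of ethoxy on an aromatic carbon, ortho to a large group, gives a 6.9-fold lower number from compound 2 to compound 3 (0.84 log units; beyond the scatter), so the number at this place clearly depends on the group it carries. Even so, 2-cyanophenyl in place of 3-bromophenyl on a saturated ring carbon gives a 12-fold higher number from compound 1 to compound 3 (1.09 log units; beyond the scatter), so cyano at this place does not close the gap to compound 1. Nothing measured here accounts for either step.

From the compounds shown here alone, whether an amine or a carboxylic acid on this aromatic carbon would shift the number further remains open. So does how cyano would behave on the carbon that carries bromo in compound 1.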